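This account rests on a few compounds, and the source may have more. Where it says the series, first, only, none or still open, it means among the compounds named here.

Of the compounds shown here, three that share one core have been measured in an assay on membranes from brain for displacement of a labelled ligand from Neuronal acetylcholine receptor; alpha4/beta2 (Rattus norvegicus), with a stated time of 3 h; a higher number here means a weaker inhibitor, a lower number a stronger inhibitor. Compound 1 `CC(=O)c1ccc(/C=C2\CCCN=C2c2cccnc2)cc1` gives 4490 nM. In this assay compound 2 `FC(F)Oc1ccc(/C=C2\CCCN=C2c2cccnc2)cc1` gives 1160 nM, and compound 3 `CCCc1ccc(/C=C2\CCCN=C2c2cccnc2)cc1` gives 890 nM. Compound 3 holds the lowest of the three numbers; its nearest neighbour is compound 2, and those two values lie within the usual scatter of each other, as the step of a 1.3-fold lower number from compound 2 to compound 3 (0.12 log units; within the scatter) shows. The widest gap is a 5.0-fold lower number from compound 1 to compound 3 (0.70 log units; beyond the scatter), and the remaining step is a 3.9-fold lower number from compound 1 to compound 2 (0.59 log units; beyond the scatter).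

Compound 4 `Clc1ccc(/C=C2\CCCN=C2c2cccnc2)cc1` has not yet been measured. It differs from compound 3 in one place: chloro in place of propyl on an aromatic carbon. None of the three measured steps involves a chloro group, so none bears on this change directly. The steps that moved beyond the scatter both started from acetyl, whereas the exchange between difluoromethoxy and propyl stayed within it. With only these to go on, the chloro group is expected to leave the number near where compound 3 stands, with no step beyond the scatter: a 1.1-fold higher number from compound 3 to compound 4 (0.05 log units; within the scatter). Compound 4 is therefore estimated at 1000 nM, with a range from 400 nM to 2500 nM.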

Compound 4, inhibition constant: 970 nM
Beside the measured number, compound 4's estimate is 1.0-fold (0.01 log units) above it; measured number inside the range.
By their numbers in this assay, from the lowest: compounds 3, 4 and 2 (each within the scatter of the next); then compound 1.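

On the aromatic carbon para to a large group, chloro brings one heavy atom where propyl brought three, yet in this assay this smaller group leaves the number within the scatter (a 1.1-fold higher number from compound 3 to compound 4 (0.04 log units; within the scatter)), and the same holds for chloro against difluoromethoxy (a 1.2-fold lower number from compound 2 to compound 4 (0.08 log units; within the scatter)). Three different groups at this position, the propyl of compound 3, the difluoromethoxy of compound 2 and the chloro of compound 4, now give values within the scatter of one another, and compound 1 goes against this, as the step to chloro also moves beyond the scatter (a 4.6-fold lower number from compound 1 to compound 4 (0.67 log units; beyond the scatter)) in the same direction as the two earlier steps away from acetyl. No measurement here explains why acetyl stands apart or why the other three groups stay together.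

On these data alone, it remains open whether this shared level would hold for an amine, a carboxylic acid or a longer chain such as hexyl at the same position, or whether any of these would stand apart as acetyl does. As far as these compounds go, it is also open whether another group with a carbonyl, such as an amide, would fall with compound 1 or with the other three compounds.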